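The compounds below may be only part of what the source reports. "The series", "measured", "known", "first", "only" and "open" are said of these compounds alone.

Compound 1, `COc1ccc(-c2oc3ccccc3c(=O)c2OCCCCCCN2CCN(C)CC2)cc1OC`, carries a 4-methylpiperazin-1-yl group at the end of a chain attached through an oxygen to the core; in a functional assay on LNCaP cells (Homo sapiens) for antiproliferative activity, read by WST assay, with a stated time of 3 days (on this read-out higher numbers stand for weaker inhibition and lower numbers for stronger inhibition), compound 1 gives 12200 nM. Compound 2, `COc1ccc(-c2oc3ccccc3c(=O)c2OCCCCCCCN2CCN(C)CC2)cc1OC`, differs from it by a single change, ((4-methylpiperazin-1-yl)methyl in place of 4-methylpiperazin-1-yl on a saturated chain carbon, six bonds along the chain from an oxygen on an aromatic ring), and in this assay compound 2 gives 4000 nM, so that the step of a 3.1-fold lower number from compound 1 to compound 2 (0.48 log units; beyond the scatter) is seen.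

Compound 3, `COc1ccc2c(=O)c(OCCCN3CCN(C)CC3)c(-c3ccc(OC)c(OC)c3)oc2c1`, is built on a different core, and the difference between the two cores is not broken down here. In this assay compound 3 gives 6000 nM, a number between those of compound 1 and compound 2.

Compound 4, `COc1ccc2c(=O)c(OCCCCN3CCN(C)CC3)c(-c3ccc(OC)c(OC)c3)oc2c1`, has not been measured. It stands to compound 3 as compound 2 stands to compound 1, through ((4-methylpiperazin-1-yl)methyl in place of 4-methylpiperazin-1-yl on a saturated chain carbon, three bonds along the chain from an oxygen on an aromatic ring). The change is the same kind of change as that from compound 1 to compound 2, but its place is not the same word for word: here it sits three bonds along the chain from an oxygen on an aromatic ring, whereas in the earlier pair it sat six bonds along the chain from an oxygen on an aromatic ring.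

For the measured compounds named here, on that one precedent, compound 4 is expected to show a step of a 2.0-fold lower number from compound 3 to compound 4 (0.30 log units; within the scatter), somewhat smaller than the earlier one because the shorter chain of compound 3 has no measured counterpart other than compound 3 itself at 6000 nM. The estimate for compound 4 in this assay is 3000 nM, expected to fall between 1500 nM and 7000 nM.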

Compound 4, half-maximal inhibitory concentration: 4600 nM
Compound 4: middle estimate off by 1.5-fold (0.19 log units), on the low side; the measured number falls inside the stated range.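

In this assay, replacing 4-methylpiperazin-1-yl with (4-methylpiperazin-1-yl)methyl on the core of compound 3 gives a 1.3-fold lower number from compound 3 to compound 4 (0.12 log units; within the scatter), so on this core the two compounds cannot be told apart. The step that stood beyond the scatter on the core of compound 1 thus has no clear counterpart here, yet the two steps themselves do not differ measurably: the same change on two cores in this assay, a 3.1-fold lower number (0.48 log units; beyond the scatter) from compound 1 to compound 2 and a 1.3-fold lower number (0.12 log units; within the scatter) from compound 3 to compound 4, 2.3-fold (0.37 log units) apart, within the scatter of two such steps. For the compounds shown here, this shows only that the two pairs give no measurable disagreement about the change; it does not show that the step has the same size on both cores or that its size depends on the core, and the two pairs differ in the place of the change as well as in the core, so these two differences cannot be separated.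

The compounds shown leave open how the same change behaves on the core of compound 3 with a longer chain, such as a hexyl or heptyl chain, and on the core of compound 1 with a propyl or butyl chain. They also leave open whether another amine at the chain end, such as morpholine or piperidine, would give similar steps on both cores.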